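A Thiophene Isomer Swap Tested at One Serotonin Receptor

The source may hold more compounds than are shown below. What is called first, only, known or untested is meant among the compounds shown, and "the series" means these compounds.

Measured so far:
Compound 1, `OC[C@H](NC1CCN(CCCc2c[nH]c3ccc(-n4ccnc4)cc23)CC1)c1ccccc1`: 0.8 nM
Compound 2, `CN(Cc1cccs1)C1CCN(CCCc2c[nH]c3ccc(-n4cnnc4)cc23)CC1`: 3.5 nM
Compound 3, `CC(=O)Nc1ccc([C@H](C)NCC2CCN(CCCc3c[nH]c4ccc(-n5cnnc5)cc34)CC2)cc1`: 3 nM

All three compounds were tested in an assay on CHO cells for agonist activity at 5-hydroxytryptamine receptor 1D (Homo sapiens), read by GTPgammaS binding; on this read-out higher numbers stand for an effect only at larger amounts of compound and lower numbers for an effect already at smaller amounts. Compound 2 gives the highest number of the three, but the gap to compound 3 is within the usual scatter of this kind of measurement, so those two cannot be told apart. Only compound 1 stands apart from compound 2, with a clearly lower number, which means an effect already at smaller amounts of compound.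

Compound 4, `CN(Cc1ccsc1)C1CCN(CCCc2c[nH]c3ccc(-n4cnnc4)cc23)CC1`, has not yet been measured. It differs from compound 2 in a single place: thiophen-3-yl in place of thiophen-2-yl on a saturated chain carbon bound to an amine nitrogen. The two rings have the same atoms, joined differently.

For the measured compounds named here, no pair of measured compounds tests this kind of change, so there is no measured step to lean on. The expectation is a step of no size beyond the scatter in this assay, and the estimated step is no change at the digits printed from compound 2 to compound 4 (within the scatter). Compound 4 is therefore expected to give about 3.5 nM, within a range from 1.5 nM to 8 nM.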

Compound 4, half-maximal effective concentration: 4.2 nM
Compound 4: middle estimate off by 1.2-fold (0.08 log units), on the low side; low and high end bracket the measured number.
By their numbers in this assay, from the lowest: compound 1; then compounds 3, 2 and 4 (each within the scatter of the next).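

In this assay, putting thiophen-3-yl in place of thiophen-2-yl on a saturated chain carbon bound to an amine nitrogen gives a 1.2-fold higher number from compound 2 to compound 4 (0.08 log units; within the scatter), and this is the only pair shown that differs in just one place. At this position, then, the two ring isomers cannot be told apart on this read-out: the same atoms, joined to the chain carbon in a different way, leave the number where repeated measurements could have put it anyway. Nothing measured here explains why the two isomers behave alike.

The compounds shown leave open whether a furan ring or a pyridine ring at this same place would also stay within the scatter of compound 2, or whether a plain methyl group on the amine nitrogen, with no ring at all, would bring a real change. They also leave open whether the thiophene swap would stay this small on the core of compound 1, so the result holds for this one pair only.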